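This account rests on a few compounds, and the source may have more. Where it says the series, first, only, none or still open, it means among the compounds named here.

Measured in a functional assay on MCF7 cells (Homo sapiens) for cytotoxicity, read by MTT assay, with a stated time of 2 days; a lower number here means that less compound is tolerated, a higher number that more compound is tolerated:
compound 1 `CC(=O)c1cc(-c2ccccc2)cc2cc(-c3ccc(F)cc3)[nH]c12`: > 100000 nM, a limit of the assay
compound 2 `CC(=O)c1cc(-c2ccc(F)cc2)cc2cc(-c3ccc(F)cc3)[nH]c12`: 87400 nM
compound 3 `COc1ccc(-c2cc3cc(-c4ccc(F)cc4)cc(C(C)=O)c3[nH]2)cc1`: > 100000 nM, a limit of the assay

For the measured compounds named here, compound 2 holds the only number in this assay; the other two results are limits, as the limit of > 100000 nM in this assay, at which 2 of the 3 values shown sit, records. Compound 4 `CC(=O)c1cc(/C=C/c2ccccc2)cc2cc(-c3ccc(F)cc3)[nH]c12` has not yet been measured. It differs from compound 2 by 2-phenylethenyl in place of 4-fluorophenyl on an aromatic carbon.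

Going by the values given here, two measured steps bear on this change: an at least 1.1-fold lower number from compound 1 to compound 2 (0.05 log units; that floor lies within the scatter) and an at least 1.1-fold higher number from compound 2 to compound 3 (0.05 log units; that floor lies within the scatter). Each of them alters a single substituent on the 4-fluorophenyl group that leaves in compound 4, and each stays within the scatter, with one side of the comparison being a limit. Neither step replaces the whole 4-fluorophenyl group by a 2-phenylethenyl group, so they serve only as a rough guide to how much this part of the molecule tolerates. Since compound 2 already lies near the upper reach of this assay and the neighbouring changes moved little, the step to compound 4 is expected to be small, a 1.0-fold higher number from compound 2 to compound 4 (0.01 log units; within the scatter), with a real chance that only a limit is returned. Compound 4 is estimated at 90000 nM, within 40000 nM to 200000 nM.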

Compound 4, concentration lethal to 50% of the cells: > 100000 nM
Compound 4: a limit, no number; the forecaster's own chance of this, stated with the estimate: 55%; middle value at least 1.1-fold (0.04 log units) away from the limit.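

Earlier steps only altered a substituent on the aromatic group at this position, whereas here the whole 4-fluorophenyl group gives way to 2-phenylethenyl, which brings a double bond outside aromatic rings. In this assay this larger change gives an at least 1.1-fold higher number from compound 2 to compound 4 (0.05 log units; that floor lies within the scatter), so even replacing the whole group at this position, meta to an acetyl group, does not produce a clear move towards a lower number. Compound 2 remains the only compound here with a number, and the step from compound 1 to compound 4 cannot be read because both results are limits: the limit of > 100000 nM in this assay, at which 3 of the 4 values shown sit.

Going by these compounds, how far the true values of compound 1, compound 3 and compound 4 lie beyond that limit remains open, and with it the real size of any difference from compound 2. Also open, on these data alone, is whether this position can give a clearly lower number in this assay with a different kind of group, such as an amine or a carboxylic acid on the aromatic ring, or a longer chain in place of 2-phenylethenyl.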